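Methoxy in Place of Fluoro on Compound 4

A few compounds are considered here, and "the series" means these few. Any claim that something is new, unique, unknown or untested is made for them only; others in the source may bear on it.

Compound 3 `Cc1c(OC[C@@H](C)COc2ccc(C(=O)O)c(F)c2)ccc(C(=O)CC(C)(C)C)c1O` is tested in an assay for positive allosteric modulation of metabotropic glutamate receptor 2 (Rattus norvegicus) (on this read-out lower numbers stand for an effect already at smaller amounts and higher numbers for an effect only at larger amounts of compound), where compound 3 gives 261 nM. Among the three compounds measured so far it holds the second highest number. Compound 2 `Cc1c(OC[C@@H](C)COc2ccc(C(=O)O)cc2F)ccc(C(=O)CC(C)(C)C)c1O` gives 222 nM in this assay, and the step of a 1.2-fold higher number from compound 2 to compound 3 (0.07 log units; within the scatter) stays within the scatter. Compound 1 `Cc1cc(C(=O)O)ccc1OC[C@H](C)COc1ccc(C(=O)CC(C)(C)C)c(O)c1C` gives 446 nM in this assay, and the step of a 1.7-fold lower number from compound 1 to compound 3 (0.23 log units; within the scatter) is also within the scatter.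

Compound 4 `COc1cc(OC[C@H](C)COc2ccc(C(=O)CC(C)(C)C)c(O)c2C)ccc1C(=O)O` differs from compound 3 in one place: methoxy in place of fluoro on an aromatic carbon. Within the data shown here, two measured steps bear on this change on the same six-membered aromatic ring. The step of a 2.0-fold lower number from compound 1 to compound 2 (0.30 log units; within the scatter) exchanged methyl for fluoro on an aromatic carbon, and the step of a 1.7-fold lower number from compound 1 to compound 3 (0.23 log units; within the scatter) went from the 4-carboxy-2-methylphenyl to the 4-carboxy-3-fluorophenyl group. Both stayed within the scatter, as did the step of a 1.2-fold higher number from compound 2 to compound 3 (0.07 log units; within the scatter). None of the three exchanges on that ring has moved this assay beyond the scatter, so the exchange of fluoro for methoxy is expected to produce no step beyond the scatter either. The number for compound 4 in this assay is therefore estimated at 300 nM, within a range of 130 nM to 700 nM, which means an expected step of a 1.1-fold higher number from compound 3 to compound 4 (0.06 log units; within the scatter).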

Compound 4, half-maximal effective concentration: 194 nM
Compound 4: the middle estimate sits 1.5-fold (0.19 log units) above what was measured, and the stated range covers the measured number.
By their numbers in this assay, from the lowest: compounds 4, 2, 3 and 1 (each within the scatter of the next, the first and the last beyond it).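

Among these compounds, at the carbon ortho to a carboxy group, only fluoro had been seen among the earlier compounds, so the first three compounds could not show whether this position would accept anything else. Methoxy now stands there, bringing two heavy atoms in place of one and a hydrogen-bond acceptor that fluoro is not counted as having, and in this assay the result is a 1.3-fold lower number from compound 3 to compound 4 (0.13 log units; within the scatter), so this larger group leaves the read-out where fluoro had it within the usual scatter. Nothing measured here accounts for that tolerance or says what the oxygen or the added carbon contributes, and no supporting evidence bears on the result.

The compounds shown leave open how far this tolerance extends, since a longer chain such as ethoxy or propoxy, a hydroxy group or an amine at the same carbon could each behave differently from methoxy. They also leave open what the unsubstituted ring, with only hydrogen on this carbon, would give, and so whether any group is needed here at all.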